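A few compounds are considered here, and "the series" means these few. Any claim that something is new, unique, unknown or untested is made for them only; others in the source may bear on it.

Compound 1 `CCCCCCCCn1cc(COC2(C(F)(F)F)Oc3ccccc3C=C2C(=O)OCC)nn1` in a functional assay on HeLa cells (Homo sapiens) for inhibition, read by MTT assay, with a stated time of 24 h (on this read-out higher numbers stand for weaker inhibition and lower numbers for stronger inhibition), gives > 150000 nM, a limit of the assay. Compound 2 `CCOC(=O)C1=Cc2ccccc2OC1(OCc1cn(CC(=O)Nc2ccc(OC)cc2)nn1)C(F)(F)F` gives 31900 nM. Compound 3 `CCOC(=O)C1=Cc2ccccc2OC1(OCc1cn(-c2ccccc2)nn1)C(F)(F)F` gives > 150000 nM, again a limit.

Compound 3 therefore stands at the limit, where two of the three values shown sit (the limit of > 150000 nM in this assay, at which 2 of the 3 values shown sit). Compound 4 `CCOC(=O)C1=Cc2ccccc2OC1(OCc1cn(CC(=O)Nc2ccc(I)cc2Cl)nn1)C(F)(F)F` differs from compound 3 by ((2-chloro-4-iodophenyl)carbamoyl)methyl in place of phenyl on an aromatic nitrogen. The step that bears most directly on this change is an at least 4.7-fold higher number from compound 2 to compound 3 (0.67 log units; beyond the scatter), which runs the opposite way to the change now proposed; an at least 4.7-fold lower number from compound 1 to compound 2 (0.67 log units; beyond the scatter) points in the same direction for the ((4-methoxyphenyl)carbamoyl)methyl group, while a step that the two limits leave unreadable from compound 1 to compound 3. Compound 4 is accordingly expected to return to a readable number, with an expected step of an at least 5.0-fold lower number from compound 3 to compound 4 (0.69 log units; beyond the scatter). Compound 4 is estimated at 30000 nM, between 10000 nM and 120000 nM.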

Compound 4, half-maximal inhibitory concentration: 26100 nM
Estimate against measurement, compound 4: 1.1-fold (0.06 log units) above, and the stated range covers the measured number.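

On the aromatic nitrogen, a readable number is not tied to the 4-methoxyphenyl group: exchanging it for 2-chloro-4-iodophenyl on the amide-type nitrogen gives a 1.2-fold lower number from compound 2 to compound 4 (0.09 log units; within the scatter). A second carbamoyl-bearing side chain thus also gives a readable number, with an at least 5.7-fold lower number from compound 3 to compound 4 (0.75 log units; beyond the scatter) and an at least 5.7-fold lower number from compound 1 to compound 4 (0.75 log units; beyond the scatter). Both of these steps start from a limit, not a number: the limit of > 150000 nM in this assay, at which 2 of the 4 values shown sit.

Within the data shown here, it remains open whether the aryl group on the amide nitrogen matters at all, since only two such groups appear. Also open, on these data alone, is how a side chain ending in an amine or a carboxylic acid would read.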